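A few compounds are considered here, and "the series" means these few. Any claim that something is new, unique, unknown or untested is made for them only; others in the source may bear on it.

Measured compounds:
compound 1 `COc1cc2ncnc(NNC(=S)NC(=O)c3ccccc3C)c2cc1OC` with 11100 nM
compound 2 `O=C(NC(=S)NNc1ncnc2ccccc12)c1ccc(C(F)(F)F)cc1` with 10600 nM
compound 3 `O=C(NC(=S)NNc1ncnc2ccccc12)c1cccc(Cl)c1` with 4540 nM

The three measured compounds were tested in a functional assay on MGC-803 cells (Homo sapiens) for cytotoxicity, read by MTT assay, with a stated time of 72 h; on this read-out higher numbers stand for weaker inhibition and lower numbers for stronger inhibition. Compound 1 stands at the highest number of the three. Its nearest neighbour is compound 2, whose number lies within the usual scatter of that of compound 1, so no order between the two can be claimed. Compound 3 gives the lowest number, and its gap to compound 1 lies beyond the scatter. Among the compounds with values here, no single-point step between any two measured compounds is available, so nothing can be said about how the core or the acyl group alone moves the read-out.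

Compound 4 `COc1cc2ncnc(NNC(=S)NC(=O)c3ccc(Cl)cc3)c2cc1OC` is not yet measured. It is reached from compound 1 by one change, (4-chlorophenyl in place of 2-methylphenyl on a carbonyl carbon). The shared core of compound 1 is kept unchanged. Within the data shown here, since no measured pair isolates this change, the expected size of the step rests only on the spread of the three values, which spans a modest range. A small move toward a lower number, not clearly beyond the scatter, is expected for a 1.7-fold lower number from compound 1 to compound 4 (0.23 log units; within the scatter). Compound 4 is therefore estimated at 6500 nM, with a range from 2500 nM to 16000 nM.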

Compound 4, half-maximal inhibitory concentration: 3710 nM
The estimate for compound 4 lay 1.8-fold (0.24 log units) above the measured number; measured number inside the range.
By their numbers in this assay, from the lowest: compounds 4 and 3 (each within the scatter of the next); then compounds 2 and 1 (each within the scatter of the next).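

In this assay, with the shared core of compound 1 kept unchanged, 4-chlorophenyl in place of 2-methylphenyl on a carbonyl carbon gives a 3.0-fold lower number from compound 1 to compound 4 (0.48 log units; beyond the scatter). Within the data shown here, this is the first step that isolates a single change, and it shows that the aryl group on this carbonyl can by itself move the read-out beyond the scatter, even though the two groups match in heavy-atom count and neither carries a hydrogen-bond donor or acceptor. Nothing measured on these compounds bears on why the number falls, so the step stands as an observation only.

From the compounds shown here alone, the change replaces methyl with chlorine and alters the substituent's place on the ring at once, so it remains open how 2-chlorophenyl or 4-methylphenyl would read and which of the two differences carries the step. Also open, going by these compounds, are how an amine or a carboxylic acid on this aryl ring would read, and whether the same exchange would give a similar step on the core of compound 2 and compound 3.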